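This account rests on a few compounds, and the source may have more. Where it says the series, first, only, none or still open, it means among the compounds named here.

Compound 1 `COc1cc(C2CC(c3cc4ccccc4o3)=NN2C(=O)Nc2ccccc2)ccc1O`: 116000000 nM
Compound 2 `COc1ccc(NC(=O)N2N=C(c3cc4ccccc4o3)CC2c2ccc(O)c(OC)c2)cc1`: 29000000 nM
Compound 3 `COc1cc(C2CC(c3cc4ccccc4o3)=NN2C(=O)Nc2ccc(O)c(O)c2)ccc1O`: 11000000 nM

In a functional assay on microsomes from liver (Rattus norvegicus, strain Wistar) for inhibition, with a stated time of 15 min (on this read-out lower numbers stand for stronger inhibition and higher numbers for weaker inhibition), compound 3 has the lowest number of the three, at 11000000 nM. Compound 4 `COc1cc(C2CC(c3cc4ccccc4o3)=NN2C(=O)Nc2ccc(O)cc2)ccc1O` differs from it by hydrogen in place of hydroxy on an aromatic carbon, turning 3,4-dihydroxyphenyl into 4-hydroxyphenyl. Within the data shown here, no measured step isolates this change. The closest are an 11-fold lower number from compound 1 to compound 3 (1.02 log units; beyond the scatter), which is large, and a 2.6-fold lower number from compound 2 to compound 3 (0.42 log units; beyond the scatter), which is modest. The 4-hydroxyphenyl group is a partial step back towards the groups of compound 1 and compound 2, so a modest rise in this assay is expected. The expected step is a 2.3-fold higher number from compound 3 to compound 4 (0.36 log units; beyond the scatter). For compound 4 the estimate is 25000000 nM, with an estimated range of 10000000 nM to 60000000 nM.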

Compound 4, half-maximal inhibitory concentration: 15000000 nM
The estimate for compound 4 lay 1.7-fold (0.22 log units) above the measured number; low and high end bracket the measured number.
By their numbers in this assay, from the lowest: compounds 3, 4 and 2 (each within the scatter of the next, the first and the last beyond it); then compound 1.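

Hydrogen in place of hydroxy, a 1.4-fold higher number from compound 3 to compound 4 (0.13 log units; within the scatter), shows that the hydroxy ortho to a hydroxy group is not required at this position: the 3,4-dihydroxyphenyl and 4-hydroxyphenyl groups cannot be told apart here. The single hydroxy already accounts for most of the separation from the unsubstituted phenyl, with a 7.7-fold lower number from compound 1 to compound 4 (0.89 log units; beyond the scatter), whereas hydrogen in place of methyl on that oxygen, a 1.9-fold lower number from compound 2 to compound 4 (0.29 log units; within the scatter), cannot be read as a change.

Open, on these data alone, is whether an amine or a carboxylic acid in place of that remaining hydroxy would keep this level, and how a longer chain on its oxygen would read. No supporting data bear on these steps.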